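Swapping the Thiophene on a Guanylhydrazone Compound

The compounds below may be only part of what the source reports. "The series", "measured", "known", "first", "only" and "open" are said of these compounds alone.

compound 1 `Cc1cc(-c2nc3sc(C)cn3c2/C=N/NC(=N)N)c(C)s1` gives 14100 nM
compound 2 `Cc1cn2c(/C=N/Nc3ccccn3)c(-c3ccc(Cl)c([N+](=O)[O-])c3)nc2s1` gives 15500 nM
compound 3 `Cc1cc(-c2nc3sccn3c2/C=N/NC(=N)N)c(C)s1` gives 17800 nM

These values come from a functional assay on cells (Cancer cell lines, Homo sapiens) for inhibition; a higher number here means a weaker inhibitor of growth, a lower number a stronger inhibitor of growth. Compound 1 stands level with the other two, as all three values lie within the scatter of one another. Compound 4 `Cc1cn2c(/C=N/NC(=N)N)c(-c3cccs3)nc2s1` has not yet been measured. It differs from compound 1 by thiophen-2-yl in place of 2,5-dimethylthiophen-3-yl on an aromatic carbon.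

Among the compounds with values here, no measured step changes this group alone. Within the data shown here, the one step available, a 1.3-fold higher number from compound 1 to compound 3 (0.10 log units; within the scatter), is a change elsewhere on the molecule, and it stays within the scatter. Compound 2, at 15500 nM, differs from compound 1 in more than one place, so it cannot isolate this change, although its value is within the scatter of that of compound 1. With so little evidence, no shift beyond the scatter is expected in this assay, though the uncertainty is wide. The expected step is a 1.1-fold higher number from compound 1 to compound 4 (0.03 log units; within the scatter). For compound 4 the estimated value is 15000 nM, with an expected range of 5000 nM to 40000 nM.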

Compound 4, concentration for 50% growth inhibition: 4270 nM
Estimate against measurement, compound 4: 3.5-fold (0.55 log units) above; measured number outside the range, below it.
By their numbers in this assay, from the lowest: compound 4; then compounds 1, 2 and 3 (each within the scatter of the next).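

In this assay, thiophen-2-yl in place of 2,5-dimethylthiophen-3-yl gives a 3.3-fold lower number from compound 1 to compound 4 (0.52 log units; beyond the scatter), which is beyond the scatter. The group on this aromatic carbon therefore matters in a way that the change elsewhere on the molecule, a 1.3-fold higher number from compound 1 to compound 3 (0.10 log units; within the scatter), did not show. The swap removes the methyl groups and also moves the thiophene's point of attachment, so the step carries both changes at once, and no evidence on its cause is available.

Going by these compounds, whether the step comes from the methyl groups or from the attachment point stays open; an unsubstituted thiophen-3-yl on the same aromatic carbon would separate the two. Also open, on these data alone, is how a phenyl or a furan-2-yl would compare at this position.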